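Swapping a Tetrazole Arm for a Sulfoxide Tail

This account rests on a few compounds, and the source may have more. Where it says the series, first, only, none or still open, it means among the compounds named here.

Of the compounds shown here, three built on the same core have been tested in an assay on isolated protein for binding affinity to leukotriene B4 receptor 1 (Homo sapiens), tested at 1 uM; a lower number here means less inhibition, a higher number more inhibition at the concentration tested (going by the name of the read-out). Compound 1 `CCc1cc(C(C)=O)c(O)cc1OCCCCCC(C)(C)C#N` gives 53%. Compound 2 `CCc1cc(C(C)=O)c(O)cc1OCCCCCCCC(C)(C)C#N` gives 29%. Compound 3 `CCc1cc(C(C)=O)c(O)cc1OCCCCCC(C)(C)c1nnn(C)n1` gives 66% and stands highest of the three numbers, with both steps toward it, a number 13 percentage points higher from compound 1 to compound 3 (beyond the scatter) and a number 37 percentage points higher from compound 2 to compound 3 (beyond the scatter), lying beyond the scatter.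

Compound 4 `CCc1cc(C(C)=O)c(O)cc1OCCCCCC[S+](C)[O-]` is the next candidate. Against compound 3 the change is a group of 4 heavy atoms (2 carbon, 1 oxygen, 1 sulfur; no ring) in place of a group of 9 heavy atoms (5 carbon, 4 nitrogen; one five-membered aromatic ring with 4 hetero atoms), on a saturated chain carbon, five bonds along the chain from an oxygen on an aromatic ring.

Among the measured compounds shown here, two measured steps bear on this. The step of a number 13 percentage points higher from compound 1 to compound 3 (beyond the scatter) shows that putting a 2-methyl-2H-tetrazol-5-yl in place of cyano on the same chain carbon raised the read-out modestly, so taking the tetrazole away again points toward a loss of similar size. The step of a number 24 percentage points lower from compound 1 to compound 2 (beyond the scatter) shows that a change in the tail at this place can move the number by a modest to large amount. For the measured compounds named here, no measured compound carries a sulfur-containing tail, so the new group itself is untested. A modest drop is therefore expected, of the size a number 24 percentage points lower from compound 3 to compound 4 (beyond the scatter). In this assay compound 4 is estimated to give 42%, with a range from 18% to 64%.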

Compound 4, a percentage reported as inhibition, at one concentration (the size of the read-out at that concentration, not a potency): 50%
The estimate for compound 4 lay 8 percentage points below the measured number; measured number inside the range.
By their numbers in this assay, from the lowest: compound 2; then compounds 4 and 1 (each within the scatter of the next); then compound 3.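

In this assay, the tetrazole arm turns out not to be required for a sizeable reading: a tail of 4 heavy atoms with no ring, built from carbon, sulfur and oxygen, still gives a clear reading, though replacing the arm costs something, a number 16 percentage points lower from compound 3 to compound 4 (beyond the scatter). The sulfoxide tail also cannot be told apart from the 1-cyano-1-methylethyl tail, a number 3 percentage points lower from compound 1 to compound 4 (within the scatter), while it reads better than the longer nitrile tail, a number 21 percentage points higher from compound 2 to compound 4 (beyond the scatter), so two quite different end groups can give similar numbers at this place. Nothing measured here explains why these tails fall in this order.

The compounds shown leave open how a sulfone, with a second oxygen on the sulfur, or a carboxylic acid would read on the same chain carbon. They also leave open whether a longer chain carrying the sulfoxide would lose ground as the longer nitrile tail of compound 2 does, since only one sulfur-bearing tail appears here.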